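A few compounds are considered here, and "the series" means these few. Any claim that something is new, unique, unknown or untested is made for them only; others in the source may bear on it.

Compound 1 `N#Cc1ccc(N2CCc3cc(-c4cnc5ccccc5c4)ccc3C2)cc1C(F)(F)F`: 25900 nM
Compound 2 `CCN(c1ccc(C#N)c(Cl)c1)c1cc(-c2ccoc2)ccc1C`: > 30000 nM
Compound 3 `CCN(c1cccc(-n2ccnc2)c1)c1ccc(C#N)c(Cl)c1`: > 30000 nM

In a functional assay on CWR22R cells (Homo sapiens) for antiproliferative activity, read by CCK-8 assay, with a stated time of 6 days (a lower number here means a stronger inhibitor, a higher number a weaker inhibitor), compound 1 gives a measured number, 25900 nM. For compound 2 the assay reports only a limit, > 30000 nM. Compound 3 also reaches only a limit, > 30000 nM. Compound 2 therefore sits at the weak end of what is shown, because of the limit of > 30000 nM in this assay, at which 2 of the 3 values shown sit.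

Compound 4 `CCN(c1ccc(C#N)c(Cl)c1)c1cc(-c2ccncc2)ccc1C` differs from compound 2 in one place: pyridin-4-yl in place of furan-3-yl on an aromatic carbon. For the measured compounds named here, no measured pair shows this change, so the step of a number no higher from compound 2 to compound 4 (the limit leaves the size open) is expected to stay within the scatter, with no direction that the data support. Compound 4 is thus estimated at 30000 nM, with a range from 8000 nM to 100000 nM, and a real chance that only a limit is reported.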

Compound 4, half-maximal inhibitory concentration: 1030 nM
The estimate for compound 4 lay 29-fold (1.46 log units) above the measured number, and the stated range ends above it.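

This position is not indifferent to the ring it carries: in this assay, pyridin-4-yl in place of furan-3-yl brings an at least 29-fold lower number from compound 2 to compound 4 (1.46 log units; beyond the scatter). Both groups count one hydrogen-bond acceptor, so that count does not separate them. The full size of the step stays open because compound 2 reaches only a limit: the limit of > 30000 nM in this assay, at which 2 of the 4 values shown sit.

The compounds shown leave open whether the gain depends on where the nitrogen sits in the ring, as a pyridin-3-yl group would test. They also leave open whether a non-aromatic group on this carbon, such as an aminomethyl group, could match pyridin-4-yl.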